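Azole exchange on compound 3: expected effect on binding

A few compounds are considered here, and "the series" means these few. Any claim that something is new, unique, unknown or untested is made for them only; others in the source may bear on it.

Three compounds on the shared core have numbers in an assay on CHO cells for displacement of a labelled ligand from prostaglandin E2 receptor EP3 subtype (Homo sapiens), read by radioligand binding; a lower number here means a stronger inhibitor, a higher number a weaker inhibitor. Compound 1 `CC(C)C(O)(C(=O)O)c1ccc(-c2ccc3ccccc3c2)[nH]c1=O` gives 544 nM. Compound 2 `CCn1ncc2c(F)cc(-c3ccc(C(CC)(CC)c4nnc[nH]4)c(=O)[nH]3)cc21` gives 17 nM. Compound 3 `CC(C)C(c1nnc[nH]1)c1ccc(-c2ccc3cccc(F)c3c2)[nH]c1=O` gives 12 nM, the lowest of the three numbers; its gap to compound 2 lies within the scatter, while its gap to compound 1 lies beyond it. Compound 4 `Cc1c[nH]c(C(c2ccc(-c3ccc4cccc(F)c4c3)[nH]c2=O)C(C)C)n1` has not yet been measured. It differs from compound 3 in one place: 4-methyl-1H-imidazol-2-yl in place of 4H-1,2,4-triazol-3-yl on a saturated chain carbon bound to an aromatic carbon and a saturated chain carbon. Among the compounds with values here, no measured pair on this core separates these two groups, so there is no observed step to lean on. As the counted difference shows, the change keeps a hydrogen-bond donor, gives up an acceptor and adds a heavy atom; nothing in the measured set says how that plays out. A modest weakening is expected, and the step of a 2.1-fold higher number from compound 3 to compound 4 (0.32 log units; beyond the scatter) expresses it, without confidence that it lies beyond the scatter. For compound 4 the expected value is 25 nM, with a range from 8 nM to 80 nM.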

Compound 4, inhibition constant: 12 nM
Beside the measured number, compound 4's estimate is 2.1-fold (0.32 log units) above it; low and high end bracket the measured number.
By their numbers in this assay, from the lowest: compounds 3, 4 and 2 (each within the scatter of the next); then compound 1.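

Within the data shown here, on the saturated chain carbon bound to an aromatic carbon and a saturated chain carbon, 4-methyl-1H-imidazol-2-yl in place of 4H-1,2,4-triazol-3-yl gives no change at the digits printed from compound 3 to compound 4 (within the scatter) in this assay, the first reading of a single change on the shared core. For this pair, the ring with 3 hetero atoms and the methyl-bearing ring with 2 hetero atoms cannot be told apart in binding, and both carry a hydrogen-bond donor. Nothing at hand explains why the two groups read alike.

From the compounds shown here alone, whether the donor is needed at this place stays open, as both groups have one. Going by these compounds, the separate part played by the methyl group also stays open, and a plain 1H-imidazol-2-yl, a 1H-tetrazol-5-yl or a primary amide on the same carbon would bear on these questions.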